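The compounds below may be only part of what the source reports. "The series", "measured", "known", "first", "only" and "open" are said of these compounds alone.

Working notes on the sulfonamide series, read in an ADME assay on MDCKII-LE cells (Canis lupus familiaris) for permeability (a lower number here means that the compound crosses the layer more slowly, a higher number that the compound crosses the layer faster), throughout. Going by the values given here, compound 1 (`N#CCCN([C@H](CCC(F)(F)F)C(N)=O)S(=O)(=O)c1ccc(Cl)cc1`) gives 10.2 10^-6 cm/s and compound 2 (`N#CCCCCN([C@H](CCC(F)(F)F)C(N)=O)S(=O)(=O)c1ccc(Cl)cc1`) gives 24 10^-6 cm/s in this read-out, and the one step here that leaves the scatter is modest: a 2.4-fold higher number from compound 1 to compound 2 (0.37 log units; beyond the scatter) for a chain carrying the nitrile. Compound 3 (`NC(=O)[C@@H](CCC(F)(F)F)N(CC1(c2ncon2)CC1)S(=O)(=O)c1ccc(Cl)cc1`) gives 16.4 10^-6 cm/s and stands within the scatter of both other compounds, with a 1.6-fold higher number from compound 1 to compound 3 (0.21 log units; within the scatter) and a 1.5-fold lower number from compound 2 to compound 3 (0.17 log units; within the scatter) as its two steps.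

Compound 4 (`NC(=O)[C@@H](CCC(F)(F)F)N(C[C@H]1C[C@@H](c2ncon2)C1)S(=O)(=O)c1ccc(Cl)cc1`) follows from compound 3 by one change: 3-(1,2,4-oxadiazol-3-yl)cyclobutyl in place of 1-(1,2,4-oxadiazol-3-yl)cyclopropyl on a saturated chain carbon bound to a sulfonamide nitrogen at the same place, on a saturated chain carbon bound to a sulfonamide nitrogen. The group that enters keeps the oxadiazole and has 2 defined stereocentres. Among the compounds with values here, no measured compound carries this cyclobutyl group, so the evidence is indirect. The closest guide is the pair of steps into compound 3 at this place, neither of which leaves the scatter, while the largest change seen at this place is still the modest step to compound 2 (a 2.4-fold higher number from compound 1 to compound 2 (0.37 log units; beyond the scatter)).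

No step beyond the scatter is therefore expected, and no direction is favoured in this assay. The expected step is a 1.0-fold higher number from compound 3 to compound 4 (0.02 log units; within the scatter) as an estimate. For compound 4 the estimated value is 17 10^-6 cm/s with an expected range from 9 10^-6 cm/s to 30 10^-6 cm/s in this read-out.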

Compound 4, apparent permeability: 14.1 10^-6 cm/s
Compound 4: the middle estimate sits 1.2-fold (0.08 log units) above what was measured, and the stated range covers the measured number.
By their numbers in this assay, from the lowest: compounds 1, 4, 3 and 2 (each within the scatter of the next, the first and the last beyond it).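

In this assay, going by these compounds alone, 3-(1,2,4-oxadiazol-3-yl)cyclobutyl in place of 1-(1,2,4-oxadiazol-3-yl)cyclopropyl gives a 1.2-fold lower number from compound 3 to compound 4 (0.07 log units; within the scatter) and so stays within the scatter: at this place, on a saturated chain carbon bound to a sulfonamide nitrogen, a four-membered ring with 2 defined stereocentres reads like the three-membered ring, which the earlier compounds could not show. Compound 4 also stands within the scatter of both nitrile compounds, with a 1.4-fold higher number from compound 1 to compound 4 (0.14 log units; within the scatter) and a 1.7-fold lower number from compound 2 to compound 4 (0.23 log units; within the scatter) as its steps, so that neither oxadiazole group separates from compound 1 or compound 2, although those two differ beyond the scatter from each other. No measurement that could explain these numbers accompanies the compounds shown.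

From the compounds shown here alone, what an amine or a carboxylic acid in place of the oxadiazole would give in this assay stays open, as does the reading for the other arrangement of the two stereocentres on the cyclobutyl group. Going by these compounds, it is also open whether a chain longer than 3-cyanopropyl would extend a 2.4-fold higher number from compound 1 to compound 2 (0.37 log units; beyond the scatter) or leave it as the largest step at this place.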